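A few compounds are considered here, and "the series" means these few. Any claim that something is new, unique, unknown or untested is made for them only; others in the source may bear on it.

Working notes on a short nucleoside series sharing one core. Compound 1 `CNc1nc(SC)nc2c1ncn2[C@@H]1C[C@@H](O)[C@H](CO)O1` gives 186 uM in a functional assay on NALL-1 cells (Homo sapiens); on this read-out higher numbers stand for weaker inhibition and lower numbers for stronger inhibition. Compound 2 `CN(C)c1nc(Br)nc2c1ncn2[C@@H]1C[C@@H](O)[C@H](CO)O1` gives 290 uM in this assay, and compound 3 `CSc1nc(N(C)C)c2ncn([C@@H]3C[C@@H](O)[C@H](CO)O3)c2n1` gives 188 uM. The three numbers sit close together: compound 2 shows the largest of them, but its separation from compound 3 and from compound 1 is within the scatter, so no order among the three can be read from these data.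

Two single-point steps are available. Adding a methyl on the exocyclic nitrogen, a 1.0-fold higher number from compound 1 to compound 3 (0.00 log units; within the scatter), left the number unchanged. Exchanging bromo for methylsulfanyl, a 1.5-fold lower number from compound 2 to compound 3 (0.19 log units; within the scatter), likewise stayed within the scatter.

Compound 4 `CNc1nc(Br)nc2c1ncn2[C@@H]1C[C@@H](O)[C@H](CO)O1` has not yet been measured. Against compound 2 the change is hydrogen in place of methyl on a nitrogen on an aromatic ring. Within the data shown here, the only measured step of this kind, the reverse of it between compound 1 and compound 3, moved the number by a 1.0-fold higher number from compound 1 to compound 3 (0.00 log units; within the scatter). On that basis no step beyond the scatter is expected in this assay for compound 4, and no change at the digits printed from compound 2 to compound 4 (within the scatter) is the expected shift. The estimate for compound 4 in this assay is therefore 290 uM, with a range from 150 uM to 560 uM.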

Compound 4, concentration for 50% inhibition: 230 uM
Beside the measured number, compound 4's estimate is 1.3-fold (0.10 log units) above it; low and high end bracket the measured number.
By their numbers in this assay, from the lowest: compounds 1, 3, 4 and 2 (each within the scatter of the next).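

Among these compounds, the step of a 1.3-fold lower number from compound 2 to compound 4 (0.10 log units; within the scatter) is the first reading of this change with bromo rather than methylsulfanyl on the aromatic carbon, and going from dimethylamino to methylamino again stays within the scatter in this assay: the same change on two cores in this assay, a 1.0-fold higher number (0.00 log units; within the scatter) from compound 1 to compound 3 and a 1.3-fold higher number (0.10 log units; within the scatter) from compound 4 to compound 2, 1.2-fold (0.10 log units) apart, within the scatter of two such steps. The new pair also gives a second reading of the exchange on the aromatic carbon, a 1.2-fold higher number from compound 1 to compound 4 (0.09 log units; within the scatter), this time with methylamino rather than dimethylamino on the shared core: the same change on two cores in this assay, a 1.5-fold lower number (0.19 log units; within the scatter) from compound 2 to compound 3 and a 1.2-fold lower number (0.09 log units; within the scatter) from compound 4 to compound 1, 1.2-fold (0.10 log units) apart, within the scatter of two such steps. The four compounds thus close a square, and neither the methyl on a nitrogen on an aromatic ring nor the choice of bromo or methylsulfanyl moves the number beyond the scatter on either partner.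

Open, going by these compounds, is whether a plain amino group, or a longer chain such as propyl, on that nitrogen would give a step beyond the scatter, and whether an amine or a carboxylic acid in place of bromo on the aromatic carbon would do so. On these data alone, all of these readings also come from this assay alone, so whether the two changes stay this small on any other read-out remains open.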